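This account rests on a few compounds, and the source may have more. Where it says the series, first, only, none or still open, it means among the compounds named here.

Measured so far:
compound 1 `OC[C@H]1O[C@@H](n2cnc3c(NCc4ccco4)ncnc32)[C@H](O)[C@@H]1O` — 36300 nM
compound 2 `OC[C@H]1O[C@@H](n2cnc3c(CSc4ccccc4Br)ncnc32)[C@H](O)[C@@H]1O` — 2400 nM

In an assay on isolated protein for binding affinity to Equilibrative nucleoside transporter 1 (Homo sapiens) (on this read-out lower numbers stand for stronger inhibition and higher numbers for weaker inhibition), compound 2 gives the lowest of the two numbers shown; the only measured step, a 15-fold lower number from compound 1 to compound 2 (1.18 log units; beyond the scatter), separates it from compound 1. Compound 3 `OC[C@H]1O[C@@H](n2cnc3c(CSc4ccc(Cl)c(Cl)c4)ncnc32)[C@H](O)[C@@H]1O` is the next one to be measured; the change is 3,4-dichlorophenyl in place of 2-bromophenyl on a sulfur. Among the measured compounds shown here, no measured step touches the aryl on the sulfur: the single step from compound 1 to compound 2 exchanges ((furan-2-yl)methyl)amino for ((2-bromophenyl)sulfanyl)methyl as a whole, so it gives no guide to the size or direction of this smaller change. With nothing bearing on it, no step beyond the scatter is expected in this assay, and the estimate sits at the value of compound 2 with a wide range. For compound 3 the expected value is 2500 nM (range 800 nM to 8000 nM). The expected step is therefore a 1.0-fold higher number from compound 2 to compound 3 (0.02 log units; within the scatter).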

Compound 3, half-maximal inhibitory concentration: 224 nM
Beside the measured number, compound 3's estimate is 11-fold (1.05 log units) above it, and the stated range ends above it.
By their numbers in this assay, from the lowest: compound 3; then compound 2; then compound 1.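

In this assay the aryl on the sulfur proves to be a sensitive point in its own right: an 11-fold lower number from compound 2 to compound 3 (1.03 log units; beyond the scatter), with 3,4-dichlorophenyl in place of 2-bromophenyl and the rest of the structure unchanged. The earlier step, a 15-fold lower number from compound 1 to compound 2 (1.18 log units; beyond the scatter), exchanged the whole substituent and so could not show what the aryl alone contributes. No measurement offered here explains the new step.

Bromine is replaced by two chlorine atoms and the substitution pattern changes in the same step, so the compounds shown do not separate the identity, number and placement of the halogens. A 3-chlorophenyl or 4-chlorophenyl on the same sulfur could separate these factors, while a 3,4-dimethoxyphenyl would test whether halogens are needed at all.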